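The source may report more compounds than this note shows. Statements on the series, on what has been measured and on what is new or still open speak of the compounds shown alone.

Going by the values given here, compound 2 `CNC(=O)c1ccc(Oc2cccc(NC(=S)Nc3ccc(F)c(F)c3)c2)nc1` is one of two compounds measured so far. In a functional assay on HCT-116 cells (Homo sapiens) for antiproliferative activity, read by MTT assay (on this read-out lower numbers stand for stronger inhibition and higher numbers for weaker inhibition), compound 2 gives 38200 nM, while compound 1 `CNC(=O)c1ccc(Oc2cccc(NC(=S)Nc3ccc(OC(F)(F)F)cc3)c2)nc1` gives 54700 nM in this assay; the two numbers lie within the usual scatter of each other, so compound 2 stands level with compound 1 rather than apart from it. Compound 3 `CNC(=O)c1ccc(Oc2cccc(NC(=S)Nc3ccc(C)cc3)c2)nc1` differs from compound 2 in one place: 4-methylphenyl in place of 3,4-difluorophenyl on an amide-type nitrogen. Among the compounds with values here, no measured pair shows this same change, so the step from compound 2 to compound 3 in this assay is expected to be none beyond the scatter, a 1.0-fold higher number from compound 2 to compound 3 (0.02 log units; within the scatter). Compound 3 is therefore estimated at 40000 nM, with a range from 15000 nM to 110000 nM.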

Compound 3, half-maximal inhibitory concentration: 53700 nM
Beside the measured number, compound 3's estimate is 1.3-fold (0.13 log units) below it; the range from low to high includes it.
By their numbers in this assay, from the lowest: compounds 2, 3 and 1 (each within the scatter of the next).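

In this assay, 4-methylphenyl in place of 3,4-difluorophenyl on an amide-type nitrogen gives a 1.4-fold higher number from compound 2 to compound 3 (0.15 log units; within the scatter), and methyl in place of trifluoromethoxy on an aromatic carbon gives a 1.0-fold lower number from compound 1 to compound 3 (0.01 log units; within the scatter). A group of carbon only at this position therefore stands level with both fluorine-bearing groups, so three different substituted phenyl groups now give no separable numbers. Nothing available here accounts for this. The compounds shown leave open whether an amine or a carboxylic acid on this phenyl, or a cyclohexyl group replacing it, would give a step beyond the scatter.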